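Thiazolidinone series: aryl to piperidinyl swap on the ring carbon

The compounds below may be only part of what the source reports. "The series", "measured", "known", "first", "only" and "open" are said of these compounds alone.

Measured so far:
- compound 1, `COc1ccc(C2SCC(=O)N2c2ccc3c(C)cc(=O)[nH]c3c2)cc1OC`: 20.6%
- compound 2, `Cc1cc(=O)[nH]c2cc(N3C(=O)CSC3c3ccccc3[N+](=O)[O-])ccc12`: 24.1%

Two compounds of the series have been run in a functional assay on the whole organism (strain albino) for inhibition, with Rattus norvegicus as the target, read by paw edema, with stated times of 1 h and 3 h, at a dose of 100 mg/kg by the oral route; on this read-out lower numbers stand for less inhibition and higher numbers for more inhibition at the one dose given (going by the name of the read-out). Compound 1 gives 20.6% and compound 2 gives 24.1%. The two numbers lie within the usual scatter of each other, so on the numbers shown compound 2 does not stand apart from compound 1; both sit at a modest level of inhibition at the single dose tested. Within the data shown here, no pair of measured compounds differs in one place only, so no step within the measured set can be read off.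

The next compound is compound 3, `Cc1cc(=O)[nH]c2cc(N3C(=O)CSC3N3CCCCC3)ccc12`. It differs from compound 2 as follows: piperidin-1-yl in place of 2-nitrophenyl on a saturated ring carbon

Nothing in the measured set shows what a non-aromatic ring in this position does to the read-out; the two aryl variants tested give similar numbers. The step is therefore expected to be none beyond the scatter, with the estimate a number 4.1 percentage points lower from compound 2 to compound 3 (within the scatter) for this assay.

For compound 3 the expected value in this assay is 20%, with a likely range from 8% to 34%.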

Compound 3, a percentage reported as inhibition, in the whole organism at one dose (the size of the read-out at that dose, not a potency): 2.77%
Beside the measured number, compound 3's estimate is 17.2 percentage points above it; measured number below the stated range.
By their numbers in this assay, from the lowest: compound 3; then compounds 1 and 2 (each within the scatter of the next).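

In this assay the saturated ring carbon of the five-membered ring, next to the ring nitrogen and the ring sulfur, turns out to be a place where the substituent matters: piperidin-1-yl in place of 2-nitrophenyl gives a number 21.3 percentage points lower from compound 2 to compound 3 (beyond the scatter). Among these compounds, the earlier compounds both carry an aromatic ring at this carbon, so they could not show that the read-out at the one dose given depends on what sits here; compound 3 is the first sign that it does, and that an aromatic ring is not simply interchangeable with piperidin-1-yl at this place. No measurement at hand gives a reason for the step.

On these data alone, the change removes the aromatic ring and the nitro group and puts a ring nitrogen on this carbon all at once, so which of these carries the step stays open. Phenyl, cyclohexyl or morpholin-4-yl at the same carbon would begin to separate these features, and the response of compound 3 at doses other than the one given also remains open.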